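Chloro replaces butyl on the cinnamamide ring of compound 3

The source may report more compounds than this note shows. Statements on the series, on what has been measured and on what is new or still open speak of the compounds shown alone.

In a functional assay on HEK293 cells for activation of melanin-concentrating hormone receptor 1 (Homo sapiens), read by inositol phosphate accumulation (a higher number here means that more compound is needed for the effect, a lower number that less compound is needed), compound 3 `CCCCc1ccc(/C=C/C(=O)Nc2ccc3nc(CCC)cc(N)c3c2)cc1` gives 740 nM and sits second highest of the three numbers shown. Compound 1 `CCCc1ccc(/C=C/C(=O)Nc2ccc3nc(CCC)cc(N)c3c2)cc1` gives 3600 nM, and a 4.9-fold lower number from compound 1 to compound 3 (0.69 log units; beyond the scatter). Compound 2 `CCCc1cc(N)c2cc(NC(=O)/C=C/c3ccc(F)cc3)ccc2n1` gives 200 nM, and a 3.7-fold higher number from compound 2 to compound 3 (0.57 log units; beyond the scatter). Compound 4 `CCCc1cc(N)c2cc(NC(=O)/C=C/c3ccc(Cl)cc3)ccc2n1` carries chloro in place of butyl on an aromatic carbon. Within the data shown here, two measured steps bear on this change: an 18-fold lower number from compound 1 to compound 2 (1.26 log units; beyond the scatter), and the reverse of the butyl-for-fluoro step, a 3.7-fold higher number from compound 2 to compound 3 (0.57 log units; beyond the scatter), both showing that a small halogen in this position goes with a lower number than a propyl or butyl chain. A lower number in this assay is therefore expected for compound 4, with the step of a 3.0-fold lower number from compound 3 to compound 4 (0.47 log units; beyond the scatter) estimated. Compound 4 is expected to give about 250 nM, in the range 100 nM to 600 nM.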

Compound 4, half-maximal effective concentration: 96 nM
Estimate against measurement, compound 4: 2.6-fold (0.42 log units) above; measured number outside the range, below it.
By their numbers in this assay, from the lowest: compound 4; then compound 2; then compound 3; then compound 1.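

In this assay, chloro gives the lowest number of the four compounds at this position on the ring, with a 7.7-fold lower number from compound 3 to compound 4 (0.89 log units; beyond the scatter) against butyl and a 38-fold lower number from compound 1 to compound 4 (1.57 log units; beyond the scatter) against propyl. The two halogens also differ, with a 2.1-fold lower number from compound 2 to compound 4 (0.32 log units; beyond the scatter), so the number depends on which halogen is present and not only on halogen versus chain. No measurement shown here explains this order. On these data alone, it remains open whether bromo or methoxy at this position would fall below chloro, and whether a chain longer than butyl would lower the number further.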